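The source may report more compounds than this note shows. Statements on the series, on what has been measured and on what is new or still open speak of the compounds shown alone.

Measured in a functional assay on HL-60 cells (Homo sapiens) for antiproliferative activity, read by XTT assay, with a stated time of 72 h; a higher number here means a weaker inhibitor, a lower number a stronger inhibitor:
compound 1 `COc1ncnc2c1c(-c1cc3ccccc3o1)cn2[C@@H]1O[C@H](CO)[C@@H](O)[C@H]1O`: 4470 nM
compound 2 `COc1nc(N)nc2c1c(-c1cccs1)cn2[C@@H]1O[C@H](CO)[C@@H](O)[C@H]1O`: > 20000 nM

Compound 2 stands at the limit of > 20000 nM in this assay, at which 1 of the 2 values shown sits, so it has a limit and not a number. Compound 3 `COc1nc(N)nc2c1c(-c1cc3ccccc3o1)cn2[C@@H]1O[C@H](CO)[C@@H](O)[C@H]1O` keeps the core of compound 2 and changes one group: 1-benzofuran-2-yl in place of thiophen-2-yl on an aromatic carbon. In words, 1-benzofuran-2-yl takes the place of thiophen-2-yl on an aromatic carbon, and the incoming group brings one six-membered aromatic ring of carbon only.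

Among the compounds with values here, no measured pair shows this swap on its own, so its size has to be judged indirectly. Compound 1 carries the same 1-benzofuran-2-yl group on a different core and gives 4470 nM. That value is the ground for expecting a moderate move towards stronger inhibition in this assay, with a real chance that the reading stays at the limit. The estimated change is an at least 2.2-fold lower number from compound 2 to compound 3 (0.34 log units; beyond the scatter). For compound 3 the expected value is 9000 nM, with an estimated range of 3500 nM to 20000 nM.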

Compound 3, half-maximal inhibitory concentration: > 20000 nM
Compound 3: a limit, no number; the forecaster's own chance of this, stated with the estimate: 40%; middle value at least 2.2-fold (0.34 log units) away from the limit.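

In this assay compound 3 gives > 20000 nM, which is a limit of the assay and not a number. The exchange of thiophen-2-yl for 1-benzofuran-2-yl therefore cannot be sized, and the larger group cannot be said to help or harm on this aromatic carbon, since both compounds of the pair rest at the same limit: the limit of > 20000 nM in this assay, at which 2 of the 3 values shown sit.

Within the data shown here, the new information concerns a different place, where amino stands in place of hydrogen on an aromatic carbon while 1-benzofuran-2-yl stays fixed, and this single change gives an at least 4.4-fold higher number from compound 1 to compound 3 (0.65 log units; beyond the scatter), the first readable step and one that points to weaker antiproliferative activity with the amino group present.

From the compounds shown here alone, whether a methyl or a dimethylamino group in place of the amino would shift the reading in the same way remains open, and so does how far any such group would move it. Going by these compounds, it is also open whether thiophen-2-yl on the core of compound 1 would give a true number, which would finally allow the two aromatic groups to be compared directly.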